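Working notes: from compound 3 to compound 4

A few compounds are considered here, and "the series" means these few. Any claim that something is new, unique, unknown or untested is made for them only; others in the source may bear on it.

In an ADME assay on Caco-2 cells (Homo sapiens) for permeability, read by LC-MS, with a stated time of 2 h (a lower number here means that the compound crosses the layer more slowly, a higher number that the compound crosses the layer faster), compound 1 (`CCN(Cc1ccc(OCCN2C(=O)CCC2=O)c(C)c1)C(CC(=O)O)c1ccc(Cl)cc1`) reads 3.9 nm/s and compound 2 (`Cc1cc(CN(C)C(CC(=O)O)c2ccc(Cl)cc2)ccc1OCCn1c(=O)ccn(C)c1=O`) reads 0.6 nm/s in this small set, while compound 3 (`COc1cc(CN(CC(C)C)C(CC(=O)O)c2ccc3c(c2)CCO3)ccc1OCCN1C(=O)CCC1=O`) reads 0.2 nm/s as the lowest of the three, beyond the scatter from both others. Compound 4 (`COc1cc(CN(CC(C)C)C(CC(=O)O)c2ccc(Cl)c(F)c2)ccc1OCCN1C(=O)CCC1=O`) differs from compound 3 by one exchange (a group of 8 heavy atoms (6 carbon, 1 fluorine, 1 chlorine; one six-membered aromatic ring of carbon only) in place of a group of 9 heavy atoms (8 carbon, 1 oxygen; one five-membered non-aromatic ring with 1 hetero atom, one six-membered aromatic ring of carbon only), on a saturated chain carbon bound to an amine nitrogen and a saturated chain carbon) and has no number yet. Among the measured compounds shown here, no measured pair isolates this exchange, so any expectation is indirect. Compound 1 with 3.9 nm/s and compound 2 with 0.6 nm/s both carry a chlorophenyl group on that saturated chain carbon, yet both also differ from compound 3 elsewhere, which makes this weak support. Expected in this assay is a rise beyond the scatter, with an estimated step (a 5.0-fold higher number from compound 3 to compound 4 (0.70 log units; beyond the scatter)) of moderate size. For compound 4 the estimated value is 1 nm/s with an expected range of 0.3 nm/s to 4 nm/s at this stage.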

Compound 4, apparent permeability: 5.88 nm/s
Beside the measured number, compound 4's estimate is 5.9-fold (0.77 log units) below it; measured number outside the range, above it.
By their numbers in this assay, from the lowest: compound 3; then compound 2; then compounds 1 and 4 (each within the scatter of the next).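

In this assay, among the compounds shown here, the exchange on the saturated chain carbon bound to an amine nitrogen and a saturated chain carbon gives the first step that isolates a single place: a 29-fold higher number from compound 3 to compound 4 (1.47 log units; beyond the scatter) with the rest of the structure unchanged. This position therefore has a large hold on the number, and 4-chloro-3-fluorophenyl in place of the group of 9 heavy atoms, which holds the one hydrogen-bond acceptor of the two, carries it well beyond the scatter. Nothing measured here bears on the reason for the step.

This single pair does not separate the contribution of the chlorine from that of the fluorine, nor the loss of the oxygen from the loss of the five-membered ring. On these data alone, how a 4-cyanophenyl or a pyridine ring would read on this carbon remains open, as does whether the step holds on other amine substituents.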